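A few compounds are considered here, and "the series" means these few. Any claim that something is new, unique, unknown or untested is made for them only; others in the source may bear on it.

Two compounds of the series carry numbers in a functional assay on SN12C cells (Homo sapiens) for antiproliferative activity, with a stated time of 48 h; on this read-out higher numbers stand for lower toxicity in this test and lower numbers for higher toxicity in this test. Compound 1 `Cc1cc(O)c(C2=NN(c3ccc(S(N)(=O)=O)cc3)C(c3ccccc3Cl)C2)cc1Cl` gives 29400 nM. Within the data shown here, compound 2 `Cc1cc(O)c(C2=NN(c3ccc(S(N)(=O)=O)cc3)C(/C=C/c3ccccc3)C2)cc1Cl` gives 59400 nM, the higher of the two numbers; the single measured step, a 2.0-fold higher number from compound 1 to compound 2 (0.31 log units; beyond the scatter), is that gap. Compound 3 `COc1ccc(C2CC(c3cc(Cl)c(C)cc3O)=NN2c2ccc(S(N)(=O)=O)cc2)cc1OC` differs from compound 2 in 3,4-dimethoxyphenyl in place of 2-phenylethenyl on a saturated ring carbon. The measured step concerns the same saturated ring carbon but a different exchange, so it gives only loose guidance. Because compound 1 gives 29400 nM with an aryl group at that carbon, compound 3 is expected to move back toward it, an estimated 1.7-fold lower number from compound 2 to compound 3 (0.23 log units; within the scatter). For compound 3 the expected value in this assay is 35000 nM, range 12000 nM to 100000 nM.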

Compound 3, concentration lethal to 50% of the cells: > 100000 nM
Compound 3: a limit, no number; the forecaster's own chance of this, stated with the estimate: 10%; at least 2.8-fold (0.45 log units) between middle value and limit.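

Compound 3 stands in this assay as a limit, not a number: the limit of > 100000 nM in this assay, at which 1 of the 3 values shown sits.

An aryl group on this saturated ring carbon therefore does not by itself keep the number near that of compound 1: the change of aryl group gives an at least 3.4-fold higher number from compound 1 to compound 3 (0.53 log units; beyond the scatter). Against the 2-phenylethenyl group, the result is only a floor, an at least 1.6-fold higher number from compound 2 to compound 3 (0.22 log units; that floor lies within the scatter), so compound 3 cannot be ordered firmly against compound 2.

Going by these compounds, how far compound 3 lies past its limit remains open. Also open, on these data alone, is whether the two methoxy groups drive the step, or how an unsubstituted phenyl, a single methoxy or a carboxylic acid on that aryl ring would read.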